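From compound 1 to compound 4: a smaller group

A few compounds are considered here, and "the series" means these few. Any claim that something is new, unique, unknown or untested is made for them only; others in the source may bear on it.

In a physicochemical assay for solubility, measured as kinetic solubility (on this read-out higher numbers stand for higher solubility and lower numbers for lower solubility), compound 1 `Cc1cc(C)c(CN2CCc3c(Cl)cc([C@H](CO)[C@H]4CCOC4)c(Cl)c3C2=O)c(=O)[nH]1` gives 570000 nM as its single entry, compound 2 `Cc1cc(C)c(CN2CCc3c(Cl)cc(C(CO)c4ccon4)c(Cl)c3C2=O)c(=O)[nH]1` gives 596000 nM; 481000 nM (2 entries) over two entries, and compound 3 `COC(c1cc(Cl)c2c(c1Cl)C(=O)N(Cc1c(C)cc(C)[nH]c1=O)CC2)C1CCN(C2COC2)CC1` gives 523000 nM; 519000 nM (2 entries) over two entries. All three lie within the usual scatter of one another, so compound 1 stands level with the other two.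

Compound 4 `Cc1cc(C)c(CN2CCc3c(Cl)cc([C@@H](C)CO)c(Cl)c3C2=O)c(=O)[nH]1` differs from compound 1 by methyl in place of oxolan-3-yl on a saturated chain carbon bound to an aromatic carbon and a saturated chain carbon on a saturated chain carbon bound to an aromatic carbon and a saturated chain carbon. Among the measured compounds shown here, no measured pair isolates this change. Given how closely these three values agree, the expected 1.1-fold lower number from compound 1 to compound 4 (0.06 log units; within the scatter) stays within the scatter, with no firm direction. For compound 4 the estimated value is 500000 nM with an expected range of 250000 nM to 650000 nM in this assay for now.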

Compound 4, solubility: 143000 nM
Beside the measured number, compound 4's estimate is 3.5-fold (0.54 log units) above it; measured number below the stated range.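

In this assay, methyl in place of oxolan-3-yl on a saturated chain carbon bound to an aromatic carbon and a saturated chain carbon gives a 4.0-fold lower number from compound 1 to compound 4 (0.60 log units; beyond the scatter). This is the first step shown beyond the scatter, so this place is not indifferent to the group it carries. Repeat entries stay far closer together than this step: the several entries of compound 3 in this assay, 523000 nM; 519000 nM (2 entries)

A single pair cannot separate the loss of the ring from the loss of its oxygen. On these data alone, whether a cyclopentyl ring, an amine or a longer chain at this place would stay level with compound 1 remains open.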